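The compounds below may be only part of what the source reports. "The series", "measured", "known", "first", "only" and "open" are said of these compounds alone.

Measured so far:
compound 1, `CNC(=O)c1cc(Oc2ccc3nc(Nc4cccc(C(C)(C)C)c4)ccc3c2)ccn1`
compound 2, `CNC(=O)c1cc(Oc2ccc3nc(Nc4ccccc4Oc4ccccc4)ncc3c2)ccn1`
compound 3, `CNC(=O)c1cc(Oc2ccc3nc(Nc4cccc(C(F)(F)F)c4)ncc3c2)ccn1`

In an ADME assay on Caco-2 cells (Homo sapiens) for permeability, in the apical to basolateral direction (a lower number here means that the compound crosses the layer more slowly, a higher number that the compound crosses the layer faster), compound 1 gives < 1 10^-6 cm/s, which is a limit of the assay and not a number. In this assay compound 2 gives < 1 10^-6 cm/s, also a limit. In this assay compound 3 gives < 1 10^-6 cm/s, again a limit. Going by the values given here, compound 3 therefore stands at the limit of < 1 10^-6 cm/s in this assay, at which 3 of the 3 values shown sit; none of the three values is separated from the others, and no step between the measured compounds can be given a size or a direction. Nothing in this set shows whether any change to the group on the nitrogen moves the read-out at all.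

Compound 4, `CNC(=O)c1cc(Oc2ccc3nc(Nc4ccc(C(C)C)cc4)ncc3c2)ccn1`, is not yet measured. It differs from compound 3 by 4-isopropylphenyl in place of 3-(trifluoromethyl)phenyl on a nitrogen on an aromatic ring. Among the compounds with values here, no measured pair carries a change of this kind, so the step has no precedent here. Since compound 3 sits at the limit of < 1 10^-6 cm/s in this assay, at which 3 of the 3 values shown sit, and the two other measured compounds sit there as well, the step from compound 3 to compound 4 in this assay is expected to be a step that the limit leaves unreadable from compound 3 to compound 4, not beyond the scatter. Compound 4 is expected to give about 0.7 10^-6 cm/s in this assay, between 0.2 10^-6 cm/s and 2.5 10^-6 cm/s, most likely reported once more only as a limit.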

Compound 4, apparent permeability: < 1 10^-6 cm/s
Compound 4 ended at the assay's limit (the forecaster's own chance of this, stated with the estimate: 75%); the middle value does not contradict the limit.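

Going by these compounds alone, no step from compound 3 to compound 4 can be read in this assay, because both values are limits of the assay and not numbers: the limit of < 1 10^-6 cm/s in this assay, at which 4 of the 4 values shown sit.

The compounds shown leave open whether any change to the group on the nitrogen gives a value clear of that limit in this assay.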